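A Second Fluorine on the Aryl Ring

A few compounds are considered here, and "the series" means these few. Any claim that something is new, unique, unknown or untested is made for them only; others in the source may bear on it.

Compound 3 `COc1cc2c(Oc3ccc(NC(=O)c4nccc(-c5ccc(F)cc5)n4)cc3F)ccnc2cc1OCCCN1CCCCC1` gives 240 nM in a functional assay on NCI-H460 cells (Homo sapiens) for cytotoxicity, read by MTT assay, with a stated time of 72 h; a lower number here means a stronger inhibitor, a higher number a weaker inhibitor. Among the three measured compounds it stands second highest, with compound 2 `COc1cc2c(Oc3ccc(NC(=O)c4nccc(-c5ccc(C)cc5)n4)cc3F)ccnc2cc1OCCCN1CCCCC1` at 230 nM nearest and compound 1 `COc1cc2c(Oc3ccc(NC(=O)c4nccc(-c5ccccc5)n4)cc3F)ccnc2cc1OCCCN1CCCCC1` at 330 nM furthest; both gaps lie within the scatter. Compound 4 `COc1cc2c(Oc3ccc(NC(=O)c4nccc(-c5ccc(F)cc5F)n4)cc3F)ccnc2cc1OCCCN1CCCCC1` differs from compound 3 by fluoro in place of hydrogen on an aromatic carbon, a change that reads 4-fluorophenyl to 2,4-difluorophenyl when cut one bond further out. Within the data shown here, the one earlier step of the same kind, a 1.4-fold lower number from compound 1 to compound 3 (0.14 log units; within the scatter), stayed within the scatter, as did a 1.4-fold lower number from compound 1 to compound 2 (0.16 log units; within the scatter) and a 1.0-fold higher number from compound 2 to compound 3 (0.02 log units; within the scatter). No shift beyond the scatter is therefore expected for compound 4, and the expected step of no change at the digits printed from compound 3 to compound 4 (within the scatter) is correspondingly small. Compound 4 is estimated at 240 nM, with a range from 120 nM to 500 nM.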

Compound 4, half-maximal inhibitory concentration: 550 nM
For compound 4 the middle estimate is 2.3-fold (0.36 log units) below the measured one; the measured number lies above the stated range.
By their numbers in this assay, from the lowest: compounds 2, 3, 1 and 4 (each within the scatter of the next, the first and the last beyond it).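

In this assay, among these compounds, placing a fluoro group ortho to a large group gives the first steps beyond the scatter in this set: a 2.3-fold higher number from compound 3 to compound 4 (0.36 log units; beyond the scatter) and a 2.4-fold higher number from compound 2 to compound 4 (0.38 log units; beyond the scatter), both modest, while a 1.7-fold higher number from compound 1 to compound 4 (0.22 log units; within the scatter) stays within it. Among the compounds shown here, the swap of hydrogen for fluoro at this place on the ring therefore moves the number upward, which no earlier step on this ring did beyond the scatter. No measurement at hand explains this rise. On these data alone, whether a chloro or methoxy group at this place would give a similar rise remains open.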